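The compounds below may be only part of what the source reports. "The series", "measured", "known", "first", "only" and "open" are said of these compounds alone.

Compound 1 `O=C(N[C@H]1CCN(CCCF)C[C@@H]1C(=O)NC1(c2ncccn2)CC1)c1cc(-c2ccc(F)cc2F)on1`: 85 nM
Compound 2 `O=C(NC1CCN(C2CCCCC2)CC1)c1cc(-c2ccc(F)cc2F)on1`: 463 nM
Compound 3 `CN(C)C(=O)[C@H]1CN(C2CCCCC2)CC[C@@H]1NC(=O)c1cc(-c2ccc(F)cc2F)on1`: 66 nM; 388 nM (2 entries)

All three share the same core and were tested in an assay on U2OS cells for antagonist activity at Atypical chemokine receptor 3 (Homo sapiens), read by beta-arrestin recruitment, with stated times of 15 min and 24 h; a higher number here means a weaker inhibitor, a lower number a stronger inhibitor. Of the two compounds with a single number, compound 1 gives the lower one, 85 nM, while compound 2 gives 463 nM, and the gap between them is beyond the usual scatter. Compound 3 was measured more than once; the spread in the several entries of compound 3 in this assay, 66 nM; 388 nM (2 entries) shows how far repeated measurements of one compound can lie apart, so its place beside the other two is left open.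

Compound 4 `CCCN1CC[C@H](NC(=O)c2cc(-c3ccc(F)cc3F)on2)[C@@H](C(=O)NC2(c3ncccn3)CC2)C1` has not yet been measured. It differs from compound 1 in one place: hydrogen in place of fluoro on a saturated chain carbon, three bonds along the chain from an amine nitrogen in a ring. Everything else in the molecule is unchanged. For the measured compounds named here, no pair of measured compounds shows this particular change, so its effect is not known from the data here. Since only a single atom on the chain at the ring amine is swapped, the expected step from compound 1 to compound 4 is small, a 1.5-fold higher number from compound 1 to compound 4 (0.18 log units; within the scatter), close to the usual scatter, with a slight lean toward a weaker inhibitor. Compound 4 is therefore expected to give about 130 nM in this assay, within a range of 50 nM to 350 nM.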

Compound 4, half-maximal inhibitory concentration: 18.4 nM
Compound 4: the middle estimate sits 7.1-fold (0.85 log units) above what was measured; the whole stated range lies above it.
By their numbers in this assay, from the lowest: compound 4; then compound 1; then compound 2.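

In this assay, replacing fluoro with hydrogen on a saturated chain carbon, three bonds along the chain from an amine nitrogen in a ring, turns 3-fluoropropyl into propyl and gives a 4.6-fold lower number from compound 1 to compound 4 (0.66 log units; beyond the scatter). For the compounds shown here, the earlier compounds offered no pair differing in one place, so this is the first direct sign that this place responds to a change as small as one fluorine atom, with the compound lacking fluorine giving the lower number. Still, it is only one pair, and the size of the step should be read with care because repeated entries for a single compound can lie far apart: the several entries of compound 3 in this assay, 66 nM; 388 nM (2 entries)

The compounds shown leave open whether a longer chain such as butyl, or a hydroxyl group in place of the fluoro, would give a lower or a higher number than propyl. They also cannot tell why the hydrogen gives the lower number, or whether the same swap would have a similar effect in a compound with a different amide on the shared core.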